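The source may report more compounds than this note shows. Statements on the series, on what has been measured and on what is new or still open speak of the compounds shown alone.

Measured compounds:
Compound 1 `COc1c(OCCCN2CCNCC2)cc(O)c2c(=O)cc(-c3ccccc3)oc12`: 10100 nM in a functional assay on A549 cells (Homo sapiens) for cytotoxicity, read by MTT assay, with a stated time of 48 h; a higher number here means a weaker inhibitor, a lower number a stronger inhibitor
Compound 2 `CCCCNCCCCOc1c(O)cc(O)c2c(=O)cc(-c3ccccc3)oc12`: "not determined" (no result reported)
Compound 3 `COc1c(O)cc(O)c2c(=O)cc(-c3ccc(Cl)cc3)oc12`: "not determined" (no result reported)

Compound 2 stands without a number in this assay, and compound 3 likewise reports none, so compound 1 alone carries a value for this shared core. Compound 4 `CCN(CC)CCCOc1c(O)cc(O)c2c(=O)cc(-c3ccccc3)oc12` differs from compound 2 by diethylamino in place of (butylamino)methyl on a saturated chain carbon, three bonds along the chain from an oxygen on an aromatic ring. Among the measured compounds shown here, no step between two measured compounds is available, so the size of this change in this assay cannot be read from the data; the expectation is for no shift beyond the scatter, in either direction. Compound 4 is therefore estimated at 10000 nM, with a range from 3000 nM to 40000 nM. For the measured compounds named here, that expectation rests on compound 1, whose 10100 nM is the one number recorded here.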

Compound 4, half-maximal inhibitory concentration: > 100000 nM
Compound 4: a limit, no number; the forecaster's own chance of this, stated with the estimate: 25%; middle value at least 10-fold (1.00 log units) from the limit.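

Compound 4 gives > 100000 nM, which is a limit and not a number. With no result for compound 2, no new step can be read between compound 2 and compound 4. The compounds shown leave open what replacing (butylamino)methyl with diethylamino does in this assay.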